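Adding a second chloro: what to expect for compound 4

The source may report more compounds than this note shows. Statements on the series, on what has been measured and on what is new or still open speak of the compounds shown alone.

Three compounds have been measured in a functional assay on NCI-H226 cells (Homo sapiens) for cytotoxicity, read by sulforhodamine B assay, with a stated time of 48 h; on this read-out lower numbers stand for stronger inhibition of growth and higher numbers for weaker inhibition of growth:

Compound 1, `ClCc1ccccc1Cn1cnc2c(Cl)nc(Cl)nc21`, gives 1730 nM.
Compound 2, `ClCc1cccc(Cn2cnc3ncnc(Cl)c32)c1`, gives 3160 nM.
Compound 3, `ClCc1cccc(Cn2cnc3c(Cl)ncnc32)c1`, gives 2130 nM.

All three carry a chloromethyl group on a benzyl arm attached to a shared core; they differ in where that arm sits on the benzene ring and in how many chloro groups the core bears. On the numbers shown, compound 3 stands second highest of the three. Its nearest neighbour is compound 1, whose number is only slightly lower, and its furthest is compound 2, whose number is somewhat higher; both of these gaps fall within the usual scatter of repeated measurements, so no order among the three can be claimed.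

Compound 4, `ClCc1cccc(Cn2cnc3c(Cl)nc(Cl)nc32)c1`, has not yet been measured. It differs from compound 3 in a single place: chloro in place of hydrogen on an aromatic carbon. Compound 1 already carries two chloro groups on the same core, arranged in the same way, and its number sits close to that of compound 3, which gives no sign that a second chloro moves the result far. The step from compound 3 to compound 4 in this assay is therefore expected to be small, most likely none beyond the scatter, with at best a slight lean toward a lower number, as in a 1.2-fold lower number from compound 3 to compound 4 (0.07 log units; within the scatter). Compound 4 is estimated at 1800 nM, with a likely range from 900 nM to 3600 nM.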

Compound 4, concentration for 50% growth inhibition: 3230 nM
Beside the measured number, compound 4's estimate is 1.8-fold (0.25 log units) below it; measured number inside the range.
By their numbers in this assay, from the lowest: compounds 1, 3, 2 and 4 (each within the scatter of the next).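

In this assay, putting chloro in place of hydrogen on the aromatic carbon between two ring nitrogen atoms gives a 1.5-fold higher number from compound 3 to compound 4 (0.18 log units; within the scatter) and so stays inside the normal spread of repeat measurements. For the compounds shown here, this is the first pair in the set that differs in only one place, so it is the first direct look at this carbon, and on this read-out compound 3 and compound 4 cannot be told apart: a single chlorine added here leaves no effect that can be distinguished from scatter. No measurement at hand explains the result or says what the chloro does at this position.

Chloro is the only replacement shown on this carbon, so it remains open whether an amine, a methoxy group or a longer chain placed there would shift the number beyond the scatter. As far as these compounds go, it also remains open whether the same replacement would give an equally small step with the benzyl arm arranged as in compound 1 or with the chloro group of compound 2 on the shared core.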